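The source may hold more compounds than are shown below. What is called first, only, known or untested is meant among the compounds shown, and "the series" means these compounds.

Measured in an ADME assay on HEK293 cells (Homo sapiens) for inhibition, read by MTT assay, with stated times of 18 h and 4 h; a lower number here means a stronger inhibitor, a higher number a weaker inhibitor:
Compound 1 `CCCCCCCCCCOP(=O)(O)OCCSC(=S)N1CCCC1`: > 100000 nM (a limit)
Compound 2 `CCCCCCCCCCOP(=O)(O)OCCSC(=S)N1CCN(C)CC1`: > 100000 nM (a limit)

Compound 2 gives > 100000 nM, which is a limit of the assay and not a number. It has no readable position of its own, and the same is true of compound 1. The evidence so far comes down to the limit of > 100000 nM in this assay, at which 2 of the 2 values shown sit.

Compound 3 `CCCCCCOP(=O)(O)OCCSC(=S)N1CCN(C)CC1` changes the chain of compound 2: hydrogen in place of butyl on a saturated chain carbon, six bonds along the chain from an oxygen on an unsaturated carbon. In words, this is hydrogen in place of butyl on a saturated chain carbon, six bonds along the chain from an oxygen on an unsaturated carbon.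

Among the compounds with values here, the only measured step is a step that the two limits leave unreadable from compound 1 to compound 2. It concerns the ring end rather than the chain, and it offers no size to carry over. In this assay the expected change is a step that the limit leaves unreadable from compound 2 to compound 3, with nothing beyond the scatter anticipated and no direction favoured. For compound 3 the estimate is 120000 nM, with an expected range from 60000 nM to 250000 nM, and a reported limit is the likeliest outcome.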

Compound 3, half-maximal inhibitory concentration: > 100000 nM
Compound 3: a limit, no number; the forecaster's own chance of this, stated with the estimate: 85%; the middle value lies beyond the limit too.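

Within the data shown here, compound 3, like compound 2, gives only a limit of the assay and not a number, so no step between them can be read. The compounds shown leave open how strongly any of them inhibits and whether chain length matters, as all share one reading: the limit of > 100000 nM in this assay, at which 3 of the 3 values shown sit.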